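Naphthyl in place of methylphenyl: cytotoxicity notes on the series

The compounds below may be only part of what the source reports. "The series", "measured", "known", "first", "only" and "open" are said of these compounds alone.

Of the compounds shown here, two carry a number so far. Compound 1 `Cc1cccc(CSc2cc(Cl)c(C)cc2S(=O)(=O)/N=C(\N)n2nccc2-c2ccccc2)c1` was run in an ADME assay on HaCaT cells (Homo sapiens) for cytotoxicity, read by MTT assay, with a stated time of 72 h (on this read-out lower numbers stand for stronger inhibition and higher numbers for weaker inhibition), and compound 1 gives 10000 nM. Compound 2 `Cc1cc(-c2ccccc2)n(/C(N)=N/S(=O)(=O)c2cc(C)c(Cl)cc2SCc2ccc(C(F)(F)F)cc2)n1` was run in the same this assay and compound 2 gives 18000 nM. Among the measured compounds shown here, the two numbers sit within the usual scatter of one another, so nothing separates compound 1 from compound 2 on this read-out, and no step between measured compounds that differ in one place is available to learn from.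

Compound 3 `Cc1cc(S(=O)(=O)/N=C(\N)n2nccc2-c2ccccc2)c(SCc2cccc3ccccc23)cc1Cl` has not been measured. It differs from compound 1 by naphthalen-1-yl in place of 3-methylphenyl on a saturated chain carbon bound to a sulfur; cut one bond further out, the 3-methylbenzyl arm on sulfur becomes a (naphthalen-1-yl)methyl arm on the same saturated chain carbon bound to a sulfur. For the measured compounds named here, with two measured points in the same region and no measured step of this type, the expectation is cautious: the step from compound 1 to compound 3 in this assay is estimated as a 1.3-fold lower number from compound 1 to compound 3 (0.10 log units; within the scatter), that is, not clearly beyond the scatter, with a slight lean toward a lower number. Compound 3 is therefore expected to give about 8000 nM in this assay, within a range from 3000 nM to 25000 nM.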

Compound 3, half-maximal inhibitory concentration: 11000 nM
The estimate for compound 3 lay 1.4-fold (0.14 log units) below the measured number; the measured number falls inside the stated range.
By their numbers in this assay, from the lowest: compounds 1, 3 and 2 (each within the scatter of the next).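

Working notes on the arm on sulfur: in this assay the step is a 1.1-fold higher number from compound 1 to compound 3 (0.04 log units; within the scatter) for naphthalen-1-yl in place of 3-methylphenyl on a saturated chain carbon bound to a sulfur, which gives the series its first single-place comparison. At this place, going from one six-membered aromatic ring of carbon only to 2 such rings, and from 7 to 10 heavy atoms in the group, does not separate the two compounds on this read-out. No measurement at hand explains this result.

Still open, from the compounds shown here alone, is whether a group of another kind at this place, such as an amine or a carboxylic acid on the aromatic ring, or a longer chain between the sulfur and the ring, would produce a step beyond the scatter. Also open, going by these compounds, is whether naphthalen-2-yl would behave as naphthalen-1-yl does here, and whether this single step would hold on other members carrying a different group on the shared core.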